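Oxadiazole Replaced by an Open-Chain Group in Compound 4

The compounds below may be only part of what the source reports. "The series", "measured", "known", "first", "only" and "open" are said of these compounds alone.

Measured compounds in a functional assay for activation of Alpha-1A adrenergic receptor (Homo sapiens), read by calcium flux; a higher number here means that more compound is needed for the effect, a lower number that less compound is needed:
compound 1 `Cc1nc(-c2ccccc2NCC2=NCCN2)co1` gives 324 nM
compound 2 `Cc1noc(-c2ccccc2NCC2=NCCN2)n1` gives 661 nM
compound 3 `Cc1nc(-c2ccccc2NCC2=NCCN2)no1` gives 724 nM

Compound 3 has the highest of the three numbers, though its gap to compound 2 is within the scatter, and only compound 1 lies clearly lower. Compound 4 `CCO/N=C(\C)c1ccccc1NCC1=NCCN1` differs from compound 3 in that (a group of 6 heavy atoms (4 carbon, 1 nitrogen, 1 oxygen; no ring) in place of a group of 6 heavy atoms (3 carbon, 2 nitrogen, 1 oxygen; one five-membered aromatic ring with 3 hetero atoms), on an aromatic carbon). Among the compounds with values here, no measured step exchanges a ring for an open-chain group; the nearest comparisons are swaps among five-membered rings, a 2.2-fold higher number from compound 1 to compound 3 (0.35 log units; beyond the scatter) and a 1.1-fold higher number from compound 2 to compound 3 (0.04 log units; within the scatter), which were modest or within the scatter. On that basis compound 4 is expected to stay close to compound 3, with the change estimated as a 1.3-fold lower number from compound 3 to compound 4 (0.12 log units; within the scatter). Compound 4 is therefore estimated at 550 nM, within 150 nM to 2000 nM.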

Compound 4, half-maximal effective concentration: 52.5 nM
Beside the measured number, compound 4's estimate is 10-fold (1.02 log units) above it; the measured number lies below the stated range.
By their numbers in this assay, from the lowest: compound 4; then compound 1; then compounds 2 and 3 (each within the scatter of the next).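

In this assay the open-chain group gives a 14-fold lower number from compound 3 to compound 4 (1.14 log units; beyond the scatter) and a 13-fold lower number from compound 2 to compound 4 (1.10 log units; beyond the scatter) and even a 6.2-fold lower number from compound 1 to compound 4 (0.79 log units; beyond the scatter) in the comparison with the oxazole, so this place, on an aromatic carbon, responds far more to losing the ring than to swapping one five-membered ring for another. A five-membered aromatic ring is thus not required here for a low number. Nothing available explains why the open-chain group lowers the number.

From the compounds shown here alone, it remains open whether a longer chain or a methyl group in place of the ethyl on the oxygen would keep this low number. The compounds shown also do not say whether the double bond itself matters, as a saturated amine chain could show.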